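Same Benzyl Swap, Second Core: Expecting Unchanged Permeability

The source may report more compounds than this note shows. Statements on the series, on what has been measured and on what is new or still open speak of the compounds shown alone.

Compound 1 `COc1cccc(Oc2ccc3c(NCCCNCc4cc(F)ccc4OC)ccnc3c2)c1` and compound 2 `COc1cccc(Oc2ccc3c(NCCCNCc4cccc(OC)c4O)ccnc3c2)c1` share one core, while compound 3 `COc1ccc(F)cc1CNCCCNc1ccnc2cc(CCc3ccccc3)ccc12` and compound 4 `COc1cccc(CNCCCNc2ccnc3cc(CCc4ccccc4)ccc23)c1O` share another. The two cores differ by phenethyl in place of 3-methoxyphenoxy on an aromatic carbon. In an ADME assay for permeability, using PAMPA, with a stated time of 30 min, at pH 7.4 (a lower number here means that the compound crosses the layer more slowly, a higher number that the compound crosses the layer faster), compound 1 gives 317 10^-6 cm/s, and compound 2 gives 317 10^-6 cm/s, so no change at the digits printed from compound 1 to compound 2 (within the scatter). That structural change was 2-hydroxy-3-methoxyphenyl in place of 5-fluoro-2-methoxyphenyl on a saturated chain carbon bound to an amine nitrogen. On the other core, compound 3 gives 23 10^-6 cm/s in this assay, and a 14-fold lower number from compound 1 to compound 3 (1.14 log units; beyond the scatter). Compound 4 differs from compound 3 by 2-hydroxy-3-methoxyphenyl in place of 5-fluoro-2-methoxyphenyl on a saturated chain carbon bound to an amine nitrogen, the same change at the same kind of place. The step expected for compound 4 is no change at the digits printed from compound 3 to compound 4 (within the scatter), because the earlier instance of this change gave no change at the digits printed from compound 1 to compound 2 (within the scatter). The estimated value for compound 4 in this assay is 23 10^-6 cm/s, with a likely range from 10 10^-6 cm/s to 50 10^-6 cm/s.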

Compound 4, apparent permeability: 23 10^-6 cm/s
Compound 4: middle estimate and measured number agree at the digits printed; the measured number falls inside the stated range.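

In this assay putting 2-hydroxy-3-methoxyphenyl in place of 5-fluoro-2-methoxyphenyl gives no change at the digits printed from compound 3 to compound 4 (within the scatter) on the second core, matching the first core: the same change on two cores in this assay, no change at the digits printed (within the scatter) from compound 1 to compound 2 and no change at the digits printed (within the scatter) from compound 3 to compound 4, 1.0-fold (0.00 log units) apart, within the scatter of two such steps.

Putting phenethyl in place of 3-methoxyphenoxy gives a 14-fold lower number from compound 2 to compound 4 (1.14 log units; beyond the scatter) with the 2-hydroxy-3-methoxyphenyl group present, matching the step seen with the 5-fluoro-2-methoxyphenyl group: the same change on two cores in this assay, a 14-fold lower number (1.14 log units; beyond the scatter) from compound 1 to compound 3 and a 14-fold lower number (1.14 log units; beyond the scatter) from compound 2 to compound 4, 1.0-fold (0.00 log units) apart, within the scatter of two such steps.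

Both changes therefore carry over between these four compounds, but one pair of cores cannot show that either change would behave the same way on other cores, nor explain why these steps match.

Going by these compounds, it remains open how a phenyl group bearing a carboxylic acid or an amine would behave in this place. Also open, on these data alone, is whether the two steps would still match with a longer chain linking the two nitrogens.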